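The compounds below may be only part of what the source reports. "The series", "measured", "known", "first", "only" and "open" are said of these compounds alone.

Compound 3 `COc1cc(OC)c2c(=O)cc(/C=C/c3ccccc3)oc2c1` is one of three analogues sharing the same core and differing only in the aryl group at the end of the double bond. In a functional assay on SKHep cells (Homo sapiens) for antiproliferative activity, read by MTT assay, with a stated time of 12 h (a lower number here means a stronger inhibitor, a higher number a weaker inhibitor), compound 3 gives 26000 nM, the higher of the two numbers recorded. Compound 1 `COc1cc(OC)c2c(=O)cc(/C=C/c3ccc([N+](=O)[O-])cc3)oc2c1` carries a nitro group on the aromatic ring and gives 22000 nM in this assay. Compound 2 `COc1cc(OC)c2c(=O)cc(/C=C/c3ccncc3)oc2c1` carries a pyridin-4-yl group in place of phenyl, and in this assay compound 2 reaches only the limit of > 40000 nM, which is not a number but the ceiling of the measurement (the limit of > 40000 nM in this assay, at which 1 of the 3 values shown sits). The move from compound 1 to compound 3 shows a 1.2-fold higher number from compound 1 to compound 3 (0.07 log units; within the scatter), and that from compound 2 to compound 3 shows an at least 1.5-fold lower number from compound 2 to compound 3 (0.18 log units; that floor lies within the scatter).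

Compound 4 `COc1cc(OC)c2c(=O)cc(/C=C/c3ccc(C(F)(F)F)cc3)oc2c1` is the next step: trifluoromethyl in place of hydrogen on an aromatic carbon. Within the data shown here, the one measured step that bears directly on it, the exchange of a substituent at the same place between compound 1 and compound 3, stayed within the scatter, so no shift beyond the scatter is expected in this assay, in either direction. The estimated step from compound 3 to compound 4 is therefore no change at the digits printed from compound 3 to compound 4 (within the scatter). For compound 4 the expected value is 26000 nM, with a range from 12000 nM to 50000 nM.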

Compound 4, half-maximal inhibitory concentration: 20600 nM
Beside the measured number, compound 4's estimate is 1.3-fold (0.10 log units) above it, within the range that was stated.
By their numbers in this assay, from the lowest: compounds 4, 1 and 3 (each within the scatter of the next). At a limit, above all of these: compound 2.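

In this assay, trifluoromethyl is a second heavy substituent on the aromatic carbon para to a large group, and like nitro its exchange for hydrogen stays within the scatter (a 1.3-fold lower number from compound 3 to compound 4 (0.10 log units; within the scatter)). The direct exchange of the two substituents also stays within the scatter (a 1.1-fold lower number from compound 1 to compound 4 (0.03 log units; within the scatter)), so hydrogen, nitro and trifluoromethyl at this place cannot be told apart in compound 3, compound 1 and compound 4, a statement that covers only these three compounds and only this place. Nothing measured here gives a cause for these steps.

The compounds shown leave open whether an amine, a carboxylic acid or a longer chain at this same place would give a number that stands clear of the scatter from those of compound 1, compound 3 and compound 4. They also leave open whether trifluoromethyl or nitro on another carbon of this ring would stay as close to hydrogen as they do here.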